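This account rests on a few compounds, and the source may have more. Where it says the series, first, only, none or still open, it means among the compounds named here.

Compound 1 `Cc1ccc(NC(=O)C(C)NS(=O)(=O)c2cccc3cccnc23)c(C)c1`: > 50000 nM
Compound 2 `Cc1cccc(NC(=O)[C@@H]2CCCN2S(=O)(=O)c2cccc3cccnc23)c1`: 25500 nM
Compound 3 `Cc1ccc(NC(=O)[C@@H]2CCCN2S(=O)(=O)c2cccc3cccnc23)cc1`: 31700 nM

In an ADME assay on HEp-2 cells (Homo sapiens) for cytotoxicity (a higher number here means that more compound is tolerated, a lower number that less compound is tolerated), compound 1 gives > 50000 nM, which is a limit of the assay and not a number.

Going by the values given here, only two compounds have actual numbers. Compound 2 gives 25500 nM and compound 3 gives 31700 nM. The step between them is a 1.2-fold higher number from compound 2 to compound 3 (0.09 log units; within the scatter), so compound 3 stands level with compound 2 and the two cannot be told apart.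

Compound 4 `O=C(Nc1ccccc1)[C@@H]1CCCN1S(=O)(=O)c1cccc2cccnc12` has not yet been measured. It differs from compound 3 as follows: hydrogen in place of methyl on an aromatic carbon. In words, hydrogen replaces methyl on an aromatic carbon, para to a large group, which turns 4-methylphenyl into phenyl.

Among the compounds with values here, one measured step touches the same group, and it only exchanges 3-methylphenyl for 4-methylphenyl. Within the data shown here, no measured step removes the methyl outright, so the evidence is indirect. Compound 3 differs from compound 2 by just a 1.2-fold higher number from compound 2 to compound 3 (0.09 log units; within the scatter), which gives no reason to expect a large shift here. No step beyond the scatter is therefore expected in this assay. The estimated change is a 1.1-fold lower number from compound 3 to compound 4 (0.02 log units; within the scatter). For compound 4 the expected value is 30000 nM, with an estimated range from 16000 nM to 50000 nM.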

Compound 4, half-maximal cytotoxic concentration: 35600 nM
Beside the measured number, compound 4's estimate is 1.2-fold (0.07 log units) below it; the measured number falls inside the stated range.
By their numbers in this assay, from the lowest: compounds 2, 3 and 4 (each within the scatter of the next). At a limit, above all of these: compound 1.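

The earlier compounds shown here only moved the methyl between two places on the phenyl ring, whereas compound 4 has no methyl there at all, and this removal still leaves it within the scatter of both methyl-bearing compounds (a 1.1-fold higher number from compound 3 to compound 4 (0.05 log units; within the scatter) and a 1.4-fold higher number from compound 2 to compound 4 (0.14 log units; within the scatter)). So for compound 2, compound 3 and compound 4, having this methyl or not makes no difference that can be read in this assay, and no order can be drawn among the three. Nothing available bears on why the result is so flat.

As far as these compounds go, removing a single methyl is a small change, so it remains open whether a carboxylic acid, an amine or a longer chain at this place on the ring would also leave the number within the scatter. Compound 1 gives > 50000 nM, which is a limit of the assay and not a number, and it differs from the other compounds in more than one place, so it cannot settle what this position tolerates.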